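Compound 3 and the step to compound 4

This account rests on a few compounds, and the source may have more. Where it says the series, first, only, none or still open, it means among the compounds named here.

Compound 1 `C=C1C(=O)O[C@H]2CC3=C[C@H](C/C(C)=C/[C@@H](OC(=O)c4ccc(C(F)(F)F)cc4)[C@H]12)OC3=O` gives > 10000 nM as a limit
Compound 2 `C=C1C(=O)O[C@H]2CC3=C[C@H](C/C(C)=C/[C@@H](OC(=O)CCCCBr)[C@H]12)OC3=O` gives > 10000 nM as a limit
Compound 3 `C=C1C(=O)O[C@H]2CC3=C[C@H](C/C(C)=C/[C@@H](OC(=O)CC(C)C)[C@H]12)OC3=O` gives 2500 nM as a number

For the measured compounds named here, all three values come from a functional assay on A549 cells (Homo sapiens) for cytotoxicity, read by MTT assay, with a stated time of 48 h (on this read-out lower numbers stand for stronger inhibition and higher numbers for weaker inhibition), and compound 3 is the only one that is a number and not a limit. Compound 4 `C=C1C(=O)O[C@H]2CC3=C[C@H](C/C(C)=C/[C@@H](OC(=O)/C=C/c4cccs4)[C@H]12)OC3=O` differs from compound 3 with 2-(thiophen-2-yl)ethenyl in place of isobutyl on a carbonyl carbon. The step that bears most is an at least 4.0-fold lower number from compound 1 to compound 3 (0.60 log units; beyond the scatter) with isobutyl in place of 4-(trifluoromethyl)phenyl on a carbonyl carbon. The other measured step runs the same way as an at least 4.0-fold lower number from compound 2 to compound 3 (0.60 log units; beyond the scatter) but changes a chain. Compound 4 gives up isobutyl and takes on an aromatic ring, so a small step toward a higher number is expected in this assay and a limit is possible. The expected change is a 2.0-fold higher number from compound 3 to compound 4 (0.30 log units; within the scatter) with wide uncertainty. For compound 4 the estimated value is 5000 nM with an expected range from 1500 nM to 12000 nM in this read-out.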

Compound 4, half-maximal inhibitory concentration: 4300 nM
Compound 4: middle estimate off by 1.2-fold (0.07 log units), on the high side, within the range that was stated.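

In this assay, isobutyl and 2-(thiophen-2-yl)ethenyl on this carbonyl carbon are not told apart, with a 1.7-fold higher number from compound 3 to compound 4 (0.24 log units; within the scatter). An aromatic ring here does not by itself lead to the limit: 2-(thiophen-2-yl)ethenyl in place of 4-(trifluoromethyl)phenyl gives an at least 2.3-fold lower number from compound 1 to compound 4 (0.36 log units; beyond the scatter), and in place of 4-bromobutyl it gives an at least 2.3-fold lower number from compound 2 to compound 4 (0.36 log units; beyond the scatter). Both of these steps are bounds only, because the compounds they start from stand at a limit: the limit of > 10000 nM in this assay, at which 2 of the 4 values shown sit.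

Going by these compounds, it remains open whether the double bond or the thiophene ring matters more for keeping a measured value. On these data alone, how a plain phenyl ring or a chain ending in an amine would read at this carbonyl carbon in this assay also stays open.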